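Carbamoyl for amino on the pyridyl ether of compound 2

The source may hold more compounds than are shown below. What is called first, only, known or untested is meant among the compounds shown, and "the series" means these compounds.

Measured compounds:
compound 1, `CCc1ccc2c(c1)c(=O)c(C(=O)Nc1ccc(Oc3ncnc4[nH]ccc34)c(F)c1)c(C)n2C`, in an assay on isolated protein for inhibition of tyrosine-protein kinase receptor UFO (Homo sapiens), read by FRET and Z'-LYTE, with a stated time of 1.5 h (on this read-out lower numbers stand for stronger inhibition and higher numbers for weaker inhibition), gives 157 nM
compound 2, `CCc1ccc2c(c1)c(=O)c(C(=O)Nc1ccc(Oc3ccnc(N)c3)c(F)c1)c(C)n2C`, in this assay gives 888 nM

Among the measured compounds shown here, compound 2 carries the highest number of the two, and the one step that joins the pair, a 5.7-fold higher number from compound 1 to compound 2 (0.75 log units; beyond the scatter), is beyond the scatter. That step exchanges the whole ether-linked bicyclic group for the aminopyridine and says nothing about a change made on the aminopyridine itself.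

Compound 3, `CCc1ccc2c(c1)c(=O)c(C(=O)Nc1ccc(Oc3ccnc(C(N)=O)c3)c(F)c1)c(C)n2C`, keeps the shared core and the ether and differs from compound 2 only in carbamoyl in place of amino on an aromatic carbon. For the measured compounds named here, no measured step bears on this particular exchange; the only step in hand, from compound 1 to compound 2, concerns a different part of the molecule. The expectation therefore rests on compound 2 alone, with a wide range in either direction. A step of a 1.8-fold lower number from compound 2 to compound 3 (0.25 log units; within the scatter) is estimated, which would leave compound 3 near compound 2 rather than beyond the scatter in a known direction. For compound 3 the estimate in this assay is 500 nM, with a range from 120 nM to 2000 nM.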

Compound 3, half-maximal inhibitory concentration: 4380 nM
Estimate against measurement, compound 3: 8.8-fold (0.94 log units) below; the whole stated range lies below it.
By their numbers in this assay, from the lowest: compound 1; then compound 2; then compound 3.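

In this assay, the position next to the ring nitrogen proves sensitive to the group it carries: carbamoyl in place of amino gives a 4.9-fold higher number from compound 2 to compound 3 (0.69 log units; beyond the scatter) even though the two groups match in hydrogen-bond donor and acceptor counts, so those counts alone do not separate them here. The pyridyl ether also moves further from the bicyclic ether of compound 1 with this change, with a 28-fold higher number from compound 1 to compound 3 (1.45 log units; beyond the scatter) as a large step where the aminopyridine gave the modest 5.7-fold higher number from compound 1 to compound 2 (0.75 log units; beyond the scatter) and the order of the three now rests on steps that all lie beyond the scatter. Nothing in hand on these compounds bears on why carbamoyl fares worse than amino at this position.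

Still open, going by these compounds, is whether the higher number follows from the added carbonyl, from the loss of the amino group on the ring carbon, or from both. A methylamino group, an acetamido group or a carboxylic acid at this position would help separate these readings, and the same exchange on the bicyclic ether of compound 1 is not open to reading from the compounds shown.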